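The compounds below may be only part of what the source reports. "The series", "measured", "known", "first", "only" and "open" are said of these compounds alone.

Compound 1 `NC1CCC(Nc2nc(NCc3ccc(-c4ccccc4)nc3)c3ncn(C4CCCC4)c3n2)CC1`: 114 nM
Compound 2 `NC1CCC(Nc2nc(NCc3ccc(-c4ccsc4)nc3)c3ncn(C4CCCC4)c3n2)CC1`: 75 nM

Both values come from a functional assay on HeLa cells (Homo sapiens) for inhibition, with a stated time of 72 h; on this read-out lower numbers stand for stronger inhibition and higher numbers for weaker inhibition. Among the compounds with values here, compound 2 stands level with compound 1 here, since the one measured step is a 1.5-fold lower number from compound 1 to compound 2 (0.18 log units; within the scatter). Compound 3 `NC1CCC(Nc2nc(NCc3cc(Cl)ccc3O)c3ncn(C4CCCC4)c3n2)CC1` has not yet been measured. Its difference from compound 2 is 5-chloro-2-hydroxyphenyl in place of 6-(thiophen-3-yl)pyridin-3-yl on a saturated chain carbon bound to a nitrogen on an aromatic ring. The measured step bears on this only loosely, because a 1.5-fold lower number from compound 1 to compound 2 (0.18 log units; within the scatter) swapped just the outer ring, whereas here the whole group leaves. The data therefore give no direct size for this change, and any forecast is uncertain. A move towards weaker inhibition seems more likely than none, and the expected step is a 4.7-fold higher number from compound 2 to compound 3 (0.67 log units; beyond the scatter). For compound 3 the estimated value is 350 nM, with an expected range of 70 nM to 1800 nM.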

Compound 3, half-maximal inhibitory concentration: 750 nM
The estimate for compound 3 lay 2.1-fold (0.33 log units) below the measured number; the range from low to high includes it.
By their numbers in this assay, from the lowest: compounds 2 and 1 (each within the scatter of the next); then compound 3.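

In this assay, the earlier pair changed only the outer ring of the group on this saturated chain carbon, a swap that stayed within the scatter, whereas replacing the whole group moves the number beyond it: 5-chloro-2-hydroxyphenyl in place of 6-(thiophen-3-yl)pyridin-3-yl gives a 10-fold higher number from compound 2 to compound 3 (1.00 log units; beyond the scatter), and in place of 6-phenylpyridin-3-yl it gives a 6.6-fold higher number from compound 1 to compound 3 (0.82 log units; beyond the scatter). This position therefore responds to the group it carries, and both groups with two aromatic rings give stronger inhibition than the single-ring group here. No measurement shown accounts for this shift.

The change alters the ring count, the ring nitrogen, the hydroxyl and the chlorine all at once, so the compounds shown cannot say which of these parts matters. A plain phenyl, a 2-hydroxyphenyl or a 5-chlorophenyl at this place would help to separate them.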